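Carbamoyl replacing bromo on the bicyclic core

This account rests on a few compounds, and the source may have more. Where it says the series, first, only, none or still open, it means among the compounds named here.

Measured so far:
- compound 1, `CSc1nc2ccccn2c(=N)c1S(=O)(=O)c1ccc2ccccc2c1`: 59 nM
- compound 2, `CSc1nc2ccc(Cl)cn2c(=N)c1S(=O)(=O)c1ccccc1`: 28 nM
- compound 3, `CSc1nc2ccc(Br)cn2c(=N)c1S(=O)(=O)c1ccccc1`: 56 nM

In an assay on HeLa cells for displacement of a labelled ligand from 5-hydroxytryptamine receptor 6 (Homo sapiens) (a higher number here means a weaker inhibitor, a lower number a stronger inhibitor), compound 3 gives 56 nM, the second highest of the three numbers. Its nearest neighbour is compound 1 with 59 nM, and its furthest is compound 2 with 28 nM; both gaps lie within the scatter, so no order among the three can be read from these values.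

Compound 4, `CSc1nc2ccc(C(N)=O)cn2c(=N)c1S(=O)(=O)c1ccccc1`, is not yet measured. It differs from compound 3 in one place: carbamoyl in place of bromo on an aromatic carbon. Among the compounds with values here, the only measured step, a 2.0-fold higher number from compound 2 to compound 3 (0.30 log units; within the scatter), swaps one halogen for another and says nothing about a carbamoyl at this position; no measured pair separates a halogen from a hydrogen-bond-donating group. The expectation for compound 4 therefore rests on the narrow spread of the three values rather than on a relevant step, and the range must be set wide.

For compound 4 the estimate in this assay is 60 nM, between 15 nM and 250 nM, which means an expected step of a 1.1-fold higher number from compound 3 to compound 4 (0.03 log units; within the scatter), not beyond the scatter in either direction.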

Compound 4, half-maximal inhibitory concentration: 8.8 nM
For compound 4 the middle estimate is 6.8-fold (0.83 log units) above the measured one; measured number below the stated range.
By their numbers in this assay, from the lowest: compound 4; then compounds 2, 3 and 1 (each within the scatter of the next, the first and the last beyond it).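

In this assay this position, on an aromatic carbon two atoms from the ring nitrogen, responds to the choice of substituent: the swap of one halogen for another stayed within the scatter, whereas carbamoyl gives steps beyond it against both bromo (a 6.4-fold lower number from compound 3 to compound 4 (0.80 log units; beyond the scatter)) and chloro (a 3.2-fold lower number from compound 2 to compound 4 (0.50 log units; beyond the scatter)). Both steps are modest, but carbamoyl, which unlike either halogen carries a hydrogen-bond donor and acceptor, is not merely tolerated here and gives the lowest number of the four compounds. Nothing available accounts for this gain.

Still open, from the compounds shown here alone, is whether a nitrile, a carboxylic acid or a methyl amide at this position would follow carbamoyl or the halogens. Also open, going by these compounds, is whether carbamoyl gives a similar step alongside the sulfonyl substituent of compound 1.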